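A few compounds are considered here, and "the series" means these few. Any claim that something is new, unique, unknown or untested is made for them only; others in the source may bear on it.

Compound 1 `COc1nc(OC)c2c(ccn2C/C=C2\OC(=O)C(OCc3ccccc3)=C2OCc2ccccc2)n1`, 4700 nM; compound 2 `O=C1NC(O)(/C=C\n2cc(I)c3c(Cl)ncnc32)C(OCc2ccccc2)=C1OCc1ccccc1`, only a limit, > 250000 nM; compound 3 `O=C1O/C(=C\Cn2cnc3c(F)nc(F)c(Cl)c32)C(OCc2ccccc2)=C1OCc1ccccc1`, "not determined" (no result reported).

In a functional assay on L1210/0 cells (Mus musculus) for antiproliferative activity, read by MTT assay, with a stated time of 72 h (a lower number here means a stronger inhibitor, a higher number a weaker inhibitor), compound 1 gives 4700 nM. For compound 2 the same assay returns only a limit, > 250000 nM, and not a number. Compound 3 has no value of its own, so its standing cannot be placed on the scale; of the values shown beside it, one sits at the limit of > 250000 nM in this assay, at which 1 of the 3 values shown sits. Compound 4 `O=C1O/C(=C\Cn2cnc3cc[nH]c3c2=O)C(OCc2ccccc2)=C1OCc1ccccc1` differs from compound 3 by a group of 10 heavy atoms (6 carbon, 3 nitrogen, 1 oxygen; one five-membered aromatic ring with 1 hetero atom, one six-membered aromatic ring with 2 hetero atoms) in place of a group of 12 heavy atoms (6 carbon, 3 nitrogen, 2 fluorine, 1 chlorine; one five-membered aromatic ring with 2 hetero atoms, one six-membered aromatic ring with 1 hetero atom), on a saturated chain carbon bound to a double-bonded chain carbon. No measured pair shows a step of this kind, so neither the size nor the direction of the change can be read from what is shown. Compound 4 is expected to be a weak inhibitor, estimated at 30000 nM, with a likely range from 5000 nM to 250000 nM.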

Compound 4, half-maximal inhibitory concentration: 28000 nM
Compound 4: the middle estimate sits 1.1-fold (0.03 log units) above what was measured; the range from low to high includes it.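

In this assay, for the compounds shown here, compound 4 gives 28000 nM, but compound 3 has no number to set against it, so no step between compound 3 and compound 4 can be read. The compounds shown leave open how exchanging these two groups changes activity, and nothing shown accounts for the value of compound 4.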